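Replacing 4-methoxyphenyl with 2-fluorophenyl in a cytotoxicity test

This account rests on a few compounds, and the source may have more. Where it says the series, first, only, none or still open, it means among the compounds named here.

Compound 1 `Fc1cccc(-c2nc(Nc3ccccc3)c3ccccc3n2)c1` gives only a limit in a functional assay on U-937 cells (Homo sapiens) for cytotoxicity, read by MTT assay, with a stated time of 48 h (on this read-out lower numbers stand for stronger inhibition and higher numbers for weaker inhibition), > 50000 nM. Going by the values given here, compound 2 `COc1ccc(Nc2nc(-c3cccc(F)c3)nc3ccc(F)cc23)cc1` gives 41100 nM, the only true number so far. Compound 3 `Fc1cccc(-c2nc(Nc3ccccc3F)c3cc(F)ccc3n2)c1` differs from compound 2 by one change, 2-fluorophenyl in place of 4-methoxyphenyl on a nitrogen on an aromatic ring. Among the compounds with values here, no measured pair shows what such a swap does, so no step beyond the usual scatter is expected in this assay. In numbers, the estimate means a 1.1-fold higher number from compound 2 to compound 3 (0.04 log units; within the scatter). Compound 3 is estimated at 45000 nM, with an expected range of 18000 nM to 80000 nM.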

Compound 3, half-maximal inhibitory concentration: > 50000 nM
Compound 3: no number, only a limit; the forecaster's own chance of this, stated with the estimate: 45%; middle value at least 1.1-fold (0.04 log units) from the limit.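

In this assay, going by these compounds alone, 2-fluorophenyl in place of 4-methoxyphenyl on a nitrogen on an aromatic ring gives the first step that can be read at this position: an at least 1.2-fold higher number from compound 2 to compound 3 (0.08 log units; that floor lies within the scatter). For compound 3, the result of > 50000 nM is a limit and not a number. The step is therefore only a floor, and its true size stays unknown: the limit of > 50000 nM in this assay, at which 2 of the 3 values shown sit.

The compounds shown leave open what an amine or a carboxylic acid would do in place of 2-fluorophenyl on this nitrogen. As far as these compounds go, whether any group at this position can bring the number clearly down also remains open.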